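Benzyl variation on the shared core and cytotoxicity

This account rests on a few compounds, and the source may have more. Where it says the series, first, only, none or still open, it means among the compounds named here.

Compound 1, `CCOC(=O)c1cnc(N2CCN(Cc3ccc(C(=O)OC)cc3)CC2)nc1Oc1c(C)cc(-c2ccc(C#N)cc2)cc1C`, in an ADME assay on MT4 cells (Homo sapiens) for cytotoxicity, read by MTT assay, with a stated time of 4 days (a higher number here means that more compound is tolerated, a lower number that less compound is tolerated), gives > 125000 nM; this is a limit of the assay, not a number.
Compound 2, `CCOC(=O)c1cnc(N2CCN(Cc3cccc(Br)c3)CC2)nc1Oc1c(C)cc(-c2ccc(C#N)cc2)cc1C`, in this assay gives > 125000 nM, again a limit.
Compound 3, `CCOC(=O)c1cnc(N2CCN(Cc3ccccc3[N+](=O)[O-])CC2)nc1Oc1c(C)cc(-c2ccc(C#N)cc2)cc1C`, in this assay gives >= 78700 nM, also a limit.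

Going by the values given here, compound 1 therefore stands only at a limit, and the two other values in this assay are limits as well, so no compound in the set has a readable number. The unmeasured compound 4, `CCOC(=O)c1cnc(N2CCN(Cc3cccc(OC)c3)CC2)nc1Oc1c(C)cc(-c2ccc(C#N)cc2)cc1C`, differs from compound 1 in one place: 3-methoxyphenyl in place of 4-(methoxycarbonyl)phenyl on a saturated chain carbon bound to an amine nitrogen in a ring.

Among the compounds with values here, the steps that bear on this change are a step that the two limits leave unreadable from compound 1 to compound 2 and a step that the two limits leave unreadable from compound 1 to compound 3, and between the two variants a step that the two limits leave unreadable from compound 2 to compound 3. None of them is readable in size. Within the data shown here, the only evidence is the limit of > 125000 nM in this assay, at which 2 of the 3 values shown sit, and (the limit of >= 78700 nM in this assay, at which 1 of the 3 values shown sits), which together show that every benzyl variant so far sits at or near the top of the tested range in this assay.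

For compound 4 no step beyond the scatter is expected; the step of a number no higher from compound 1 to compound 4 (the limit leaves the size open) is expected to be flat. Compound 4 is therefore expected at 125000 nM, in the range 60000 nM to 200000 nM, most probably reported as a limit again.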

Compound 4, half-maximal cytotoxic concentration: > 125000 nM
Compound 4 ended at the assay's limit; the forecaster's own chance of this, stated with the estimate: 85%; the middle value sits exactly at the limit.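

Compound 4 also stands at a limit in this assay, so its steps from compound 1, compound 2 and compound 3 cannot be read in size: the limit of > 125000 nM in this assay, at which 3 of the 4 values shown sit.

The compounds shown leave open at what concentration any of these benzyl variants on the shared core becomes cytotoxic, and whether the benzyl substituent changes that concentration at all.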